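Aryl change on the shared core: compound 2 to compound 4

This account rests on a few compounds, and the source may have more. Where it says the series, first, only, none or still open, it means among the compounds named here.

Measured so far, in a functional assay on A549 cells (Homo sapiens) for antiproliferative activity, read by MTT assay, with a stated time of 24 h; a higher number here means a weaker inhibitor, a lower number a stronger inhibitor:
compound 1 `COc1ccc(-c2cc(/C=C/C(=O)c3ccc(OC)c(OC)c3)nc3cc(-c4ccccc4)nn23)cc1` gives 7400 nM
compound 2 `COc1ccc(-c2cc(/C=C/C(=O)c3ccccc3)nc3cc(-c4ccccc4)nn23)cc1` gives 8600 nM
compound 3 `COc1ccc(-c2cc(C(=O)/C=C/c3ccc(Cl)cc3)nc3cc(-c4ccccc4)nn23)cc1OC` gives 22000 nM

Compound 2 sits second highest of these three numbers, nearest to compound 1 and furthest from compound 3. Compound 4 `COc1cc(-c2cc(/C=C/C(=O)c3ccccc3)nc3cc(-c4ccccc4)nn23)cc(OC)c1OC` differs from compound 2 by 3,4,5-trimethoxyphenyl in place of 4-methoxyphenyl on an aromatic carbon. Among the measured compounds shown here, no measured step alters this group. For the measured compounds named here, the only single-point step, a 1.2-fold higher number from compound 1 to compound 2 (0.07 log units; within the scatter), adds methoxy groups on a different aryl and stays within the scatter, which offers little guidance for this position. For compound 4 no step beyond the scatter is therefore expected, a 1.2-fold lower number from compound 2 to compound 4 (0.09 log units; within the scatter). Compound 4 is estimated at 7000 nM, within a range of 2500 nM to 20000 nM.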

Compound 4, half-maximal inhibitory concentration: 18200 nM
For compound 4 the middle estimate is 2.6-fold (0.41 log units) below the measured one; low and high end bracket the measured number.
By their numbers in this assay, from the lowest: compounds 1 and 2 (each within the scatter of the next); then compounds 4 and 3 (each within the scatter of the next).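

In this assay, among the compounds shown here, this position responds to the choice of aryl: 3,4,5-trimethoxyphenyl in place of 4-methoxyphenyl gives a 2.1-fold higher number from compound 2 to compound 4 (0.33 log units; beyond the scatter) and is the first single-point step beyond the scatter, though a modest one. For the compounds shown here, the one earlier step, on the aryl at the carbonyl, stayed within the scatter, so methoxy groups do not read alike at the two sites in these two steps. Nothing available accounts for this step.

Still open, on these data alone, is whether an unsubstituted phenyl at this position would differ from compound 2. An amine or a carboxylic acid on this aryl also remains to be placed in the series.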